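Swapping a Dimethylphenyl for a Hydroxyphenyl on Sulfur

The source may report more compounds than this note shows. Statements on the series, on what has been measured and on what is new or still open speak of the compounds shown alone.

Of the compounds shown here, two have been measured in a functional assay on U2OS cells (Homo sapiens) for antiproliferative activity, read by MTT assay, with a stated time of 72 h; on this read-out lower numbers stand for stronger inhibition and higher numbers for weaker inhibition. Compound 1, `O=C(Cn1cc(F)c(=O)n(CC(=O)Nc2ccc(Br)cn2)c1=O)Nc1ccc(Br)cn1`, gives 5140 nM. Compound 2, `Cc1ccc(SCC(=O)Nc2ccc3nc(NC(=O)c4ccc(C(F)(F)F)cc4)sc3c2)c(C)c1`, gives 1000 nM, the lower of the two numbers; the gap between them lies beyond the usual scatter, so compound 2 is the more potent of the pair on this read-out. The two structures differ in many places at once, so nothing can be said about which part of either structure accounts for that gap.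

Compound 3, `O=C(CSc1cccc(O)c1)Nc1ccc2nc(NC(=O)c3ccc(C(F)(F)F)cc3)sc2c1`, has not yet been measured. It differs from compound 2 in one place: 3-hydroxyphenyl in place of 2,4-dimethylphenyl on a sulfur. Among the compounds with values here, no measured pair in this set shows what such a change does. With nothing to anchor the step, the change from compound 2 to compound 3 is expected to be small, about a 1.5-fold higher number from compound 2 to compound 3 (0.18 log units; within the scatter), with no clear direction. Compound 3 is therefore estimated at 1500 nM, between 400 nM and 6000 nM.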

Compound 3, half-maximal inhibitory concentration: 630 nM
Compound 3: the middle estimate sits 2.4-fold (0.38 log units) above what was measured; the measured number falls inside the stated range.
By their numbers in this assay, from the lowest: compounds 3 and 2 (each within the scatter of the next); then compound 1.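

Within the data shown here, the first comparison at this position that differs in one place only reads, in this assay, as a 1.6-fold lower number from compound 2 to compound 3 (0.20 log units; within the scatter). On this sulfur, then, 3-hydroxyphenyl can stand in place of 2,4-dimethylphenyl and the two numbers cannot be told apart on this read-out, even though the entering group carries a hydrogen-bond donor and acceptor that the leaving group lacks. No measurement shown gives any reason for this result.

The swap removes both methyl groups and adds a hydroxyl in one step, so the compounds shown cannot separate what each of these edits contributes on its own. From the compounds shown here alone, how a phenyl ring bearing an amine or a carboxylic acid would read on this sulfur also remains open.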